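The source may hold more compounds than are shown below. What is called first, only, known or untested is meant among the compounds shown, and "the series" means these compounds.

Working notes on the series in a functional assay on cells (Oocyte) for inhibition of Voltage-dependent T-type calcium channel subunit alpha-1H (Homo sapiens), tested at 100 uM; on this read-out higher numbers stand for more inhibition at the one concentration tested (going by the name of the read-out) and lower numbers for less inhibition.

Within the data shown here, compound 3 `CN1CCN(C2=Nc3ccccc3C(CC(=O)O)N2c2ccccc2)CC1` gives 15%, the second highest of the three numbers so far. Its nearest neighbour is compound 2 `O=C(O)CC1c2ccccc2N=C(N2CCOCC2)N1c1ccccc1` with 9%, and the step of a number 6 percentage points higher from compound 2 to compound 3 (within the scatter) lies within the scatter. Compound 1 `COC(=O)CC1c2ccccc2N=C(c2ccccc2)N1c1ccccc1` gives 51.5%, beyond the scatter above compound 3.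

Compound 4 `O=C(O)CC1c2ccccc2N=C(c2ccccc2)N1c1ccccc1` has yet to be measured. The change is phenyl in place of 4-methylpiperazin-1-yl on a carbon with a double bond to nitrogen. Among the measured compounds shown here, no measured step covers this exact exchange; the only bearing point is compound 1, which also carries phenyl on a carbon with a double bond to nitrogen and reads 51.5%, well above compounds 2 and 3. An upward step is therefore expected, with its size uncertain: the estimate for compound 4 is 38%, range 15% to 60%, a step of a number 23 percentage points higher from compound 3 to compound 4 (beyond the scatter).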

Compound 4, a percentage reported as inhibition, at one concentration (the size of the read-out at that concentration, not a potency): 7.2%
Beside the measured number, compound 4's estimate is 30.8 percentage points above it; measured number outside the range, below it.
By their numbers in this assay, from the lowest: compounds 4, 2 and 3 (each within the scatter of the next); then compound 1.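

At the carbon with a double bond to nitrogen, with the acid kept, phenyl is not distinguished from 4-methylpiperazin-1-yl (a number 7.8 percentage points lower from compound 3 to compound 4 (within the scatter)) or from morpholin-4-yl (a number 1.8 percentage points lower from compound 2 to compound 4 (within the scatter)). The large gap lies at the other place, on the oxygen next to a carbonyl group (a number 44.3 percentage points lower from compound 1 to compound 4 (beyond the scatter)), so the high reading goes with methyl on that oxygen, not with phenyl alone. Nothing available explains this gap.

Still open, on these data alone, is whether methyl on that oxygen gives the same gain with morpholin-4-yl or 4-methylpiperazin-1-yl on that carbon. Also open, as far as these compounds go, is how an ethyl group on that oxygen, or a primary amide in place of the carboxylic acid, would read.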